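The source may hold more compounds than are shown below. What is called first, only, known or untested is meant among the compounds shown, and "the series" means these compounds.

In an ADME assay on BJ cells (Homo sapiens), read by MTT assay, with a stated time of 72 h (a higher number here means a weaker inhibitor, a lower number a stronger inhibitor), compound 3 `Nc1nc(N)c2c(-c3ccco3)cn([C@@H]3O[C@H](CO)[C@@H](O)[C@H]3O)c2n1` gives > 100000 nM, which is a limit and not a number. Compound 1 `CNc1ncnc2c1c(-c1cccs1)cn2[C@@H]1O[C@H](CO)[C@@H](O)[C@H]1O` gives > 100000 nM, which is also a limit. Compound 2 `C#Cc1cn([C@@H]2O[C@H](CO)[C@@H](O)[C@H]2O)c2ncnc(NC)c12` gives a measured 86000 nM. Compound 3 therefore stands with compound 1 at the limit of > 100000 nM in this assay, at which 2 of the 3 values shown sit.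

Compound 4 `Nc1nc(N)c2c(-c3ccsc3)cn([C@@H]3O[C@H](CO)[C@@H](O)[C@H]3O)c2n1` has thiophen-3-yl in place of furan-2-yl on an aromatic carbon. Among the compounds with values here, no measured step makes this exchange. The nearest evidence is an at least 1.1-fold lower number from compound 1 to compound 2 (0.06 log units; that floor lies within the scatter), where thiophen-2-yl gives way to ethynyl on a different parent, so it offers only indirect guidance. That small step gives no reason to expect a change beyond the scatter in this assay, and no direction is favoured. The exchange in compound 4 also keeps a five-membered aromatic ring with 1 hetero atom in place.

The estimated step is a number no higher from compound 3 to compound 4 (the limit leaves the size open). Compound 4 is expected at 100000 nM, with an estimated range from 40000 nM to 200000 nM, and the assay may well report only a limit.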

Compound 4, half-maximal inhibitory concentration: > 100000 nM
Compound 4 ended at the assay's limit; the forecaster's own chance of this, stated with the estimate: 70%; the middle value sits exactly at the limit.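

Compound 3 and compound 4 both ended at a limit rather than a number, so no step between them can be read: the limit of > 100000 nM in this assay, at which 3 of the 4 values shown sit.

The compounds shown leave open whether thiophen-3-yl in place of furan-2-yl on an aromatic carbon changes the number at all.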